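The source may hold more compounds than are shown below. What is called first, only, known or untested is meant among the compounds shown, and "the series" means these compounds.

Compound 1 `O=C1/C(=C/c2ccccc2Cl)CCCc2ccccc21` gives 18400 nM in a functional assay on CCRF-CEM cells (Homo sapiens) for inhibition (a lower number here means a stronger inhibitor, a higher number a weaker inhibitor), the second highest of the three numbers in hand. Compound 2 `O=C1/C(=C/c2ccccc2[N+](=O)[O-])Cc2ccccc21` gives 3530 nM in this assay, and compound 3 `O=C1/C(=C/c2ccc(Cl)cc2Cl)CCCc2ccccc21` gives 407000 nM. For the measured compounds named here, the one single-point step among the measured compounds is a 22-fold higher number from compound 1 to compound 3 (1.34 log units; beyond the scatter), where chloro replaces hydrogen on an aromatic carbon; it concerns a different change and offers no direct guide here. Compound 4 `O=C1/C(=C/c2ccccc2F)CCCc2ccccc21` differs from compound 1 by fluoro in place of chloro on an aromatic carbon. Going by the values given here, no measured step covers a fluoro-for-chloro exchange, so no step beyond the scatter is expected in this assay, only a 1.1-fold higher number from compound 1 to compound 4 (0.04 log units; within the scatter). Compound 4 is therefore estimated at 20000 nM, with a range of 6000 nM to 70000 nM.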

Compound 4, half-maximal inhibitory concentration in the CCRF-CEM assay: 28200 nM
Estimate against measurement, compound 4: 1.4-fold (0.15 log units) below; low and high end bracket the measured number.
By their numbers in the CCRF-CEM assay, from the lowest: compound 2; then compounds 1 and 4 (each within the scatter of the next); then compound 3.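

In the CCRF-CEM assay, fluoro in place of chloro on this aromatic carbon, ortho to a large group, gives a 1.5-fold higher number from compound 1 to compound 4 (0.19 log units; within the scatter), so the exchange leaves the inhibition number within the scatter. In a physicochemical assay for lipophilicity (a higher number here means a more lipophilic compound, a lower number a more polar compound), compound 1 gives 5.04 and compound 4 gives 4.55, which is a number 0.49 log units lower from compound 1 to compound 4 (beyond the scatter). The partition coefficient therefore moves beyond the scatter while the inhibition number does not.

Open, on these data alone, is whether a methoxy or an amine at this position would stay as close to compound 1 in the CCRF-CEM assay. Also open, as far as these compounds go, is whether the same exchange would behave alike on compound 3.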